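From Compound 1 to Compound 4: A Fluorophenyl Exchange

This account rests on a few compounds, and the source may have more. Where it says the series, first, only, none or still open, it means among the compounds named here.

Compound 1 `COc1cccc(N2CCN(C(=O)C(C)N3C(=O)CCC3=O)CC2)c1` was tested in a functional assay on the whole organism (strain Swiss) with Mus musculus as the target, in the maximal electroshock model, with a stated time of 1 h, at a dose of 100 mg/kg by the intraperitoneal route (a lower number here means a weaker effect, a higher number a stronger effect of the compound at the dose given), where compound 1 gives 0%. Compound 3 `CC(C(=O)N1CCN(c2ccccc2F)CC1)N1C(=O)CCC1=O` gives 0% in the same test, and compound 2 `COCC(C(=O)N1CCN(c2cccc(C(F)(F)F)c2)CC1)N1C(=O)CCC1=O` gives 50%. Compound 1 thus stands level with compound 3 at the foot of the three numbers, well under compound 2. Compound 4 `CC(C(=O)N1CCN(c2ccc(F)cc2)CC1)N1C(=O)CCC1=O` differs from compound 1 by 4-fluorophenyl in place of 3-methoxyphenyl on an amine nitrogen in a ring. Going by the values given here, the one comparable change that has been measured, no change at the digits printed from compound 1 to compound 3 (within the scatter), lies within the scatter. Among the compounds with values here, compound 2 differs from compound 1 in two places, so its higher value offers no single step to lean on. On that basis the step of a number 10 percentage points higher from compound 1 to compound 4 (within the scatter) is expected to be small. Compound 4 is therefore estimated at 10%, within a range of 0% to 40%.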

Compound 4, a percentage reported as activity, at one dose (the size of the read-out at that dose, not a potency): 0%
Compound 4: middle estimate off by 10 percentage points, on the high side, and the stated range covers the measured number.
By their numbers in this assay, from the lowest: compounds 1, 3 and 4 (each within the scatter of the next); then compound 2.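

In this assay the 4-fluorophenyl group on the amine nitrogen in a ring gives no change at the digits printed from compound 1 to compound 4 (within the scatter), making it the second replacement of 3-methoxyphenyl at this position to leave the read-out unmoved. Exchanging 2-fluorophenyl for 4-fluorophenyl gives no change at the digits printed from compound 3 to compound 4 (within the scatter), so the two fluorophenyl groups read alike at this dose. No evidence is available that bears on this result. The compounds shown leave open how a 4-chlorophenyl group or a plain phenyl group would read at this position, and whether the 3-trifluoromethylphenyl group of compound 2 would give any activity on the core of compound 1.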